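Methyl to ethyl on the carbamate of compound 1

The compounds below may be only part of what the source reports. "The series", "measured", "known", "first", "only" and "open" are said of these compounds alone.

Going by the values given here, compound 1, with the structure `COC(=O)N(C)CC#CCN1CCCC1`, is the only one of three measured compounds that returns a number in a functional assay on the whole organism for agonist activity, with Mus musculus as the target; on this read-out lower numbers stand for an effect already at smaller amounts and higher numbers for an effect only at larger amounts of compound: there compound 1 gives 3 mg/kg. Compound 2, `COC(=O)N(C)CC#CCn1cncc1C`, carries a different core; the difference between the two cores is not broken down here. In this assay compound 2 reaches only the limit > 100 mg/kg, which is a limit of the assay and not a number. Compound 3, `COC(=O)N(C)C(C)C#CCn1cncc1C`, differs from compound 2 by methyl in place of hydrogen on a saturated chain carbon bound to an amide-type nitrogen and a triple-bonded carbon. In this assay compound 3 likewise stops at the limit > 100 mg/kg, a limit and not a number. So the step that the two limits leave unreadable from compound 2 to compound 3 stays unreadable, because the limit of > 100 mg/kg in this assay, at which 2 of the 3 values shown sit, hides it.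

Compound 4, `CCOC(=O)N(C)CC#CCN1CCCC1`, is not yet measured. It differs from compound 1 by methyl in place of hydrogen on a saturated chain carbon bound to an oxygen next to a carbonyl group. Among the compounds with values here, this is the same kind of change as the one from compound 2 to compound 3, but not the same: there the methyl sits on a saturated chain carbon bound to an amide-type nitrogen and a triple-bonded carbon, here on a saturated chain carbon bound to an oxygen next to a carbonyl group. The measured pair says nothing about its size. The estimate for compound 4 rests on compound 1 alone and its value 3 mg/kg, a single carbon being added: the expected step is a 2.0-fold higher number from compound 1 to compound 4 (0.30 log units; within the scatter). In this assay compound 4 is expected to give about 6 mg/kg, most likely between 1.5 mg/kg and 25 mg/kg.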

Compound 4, dose for half-maximal effect: > 100 mg/kg
Compound 4 gave a limit, no number; the forecaster's own chance of this, stated with the estimate: 10%; middle value at least 16-fold (1.22 log units) from the limit.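

On the core of compound 1, the change from methoxycarbonyl to ethoxycarbonyl gives an at least 33-fold higher number from compound 1 to compound 4 (1.52 log units; beyond the scatter) in this assay, so on this core one added carbon at this place is enough to take the compound out of the measurable range. Among the compounds shown, the ethoxycarbonyl group stands on this core only, so the step shows what the change does here and does not show whether it would do the same on the core of compound 2. The only step on that other core, a methyl at a different place, cannot be read, and it offers no comparison because both of its compounds sit at a limit, as compound 4 now does too: the limit of > 100 mg/kg in this assay, at which 3 of the 4 values shown sit.

On these data alone, it remains open how far beyond its limit compound 4 really lies, and whether a propoxycarbonyl group, with its longer chain, would behave like the ethoxycarbonyl group on the core of compound 1. As far as these compounds go, it also remains open whether an ethoxycarbonyl group on the core of compound 2 could give a readable result at all, since that core already stands at the limit with methoxycarbonyl.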